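The compounds below may be only part of what the source reports. "The series", "measured", "known", "first", "only" and "open" are said of these compounds alone.

Measured compounds:
Compound 1 `C=C1C(=O)[C@]23C[C@@]1(O)CC[C@H]2c1ccc(O)c(C)c1[C@@H]3Cn1cc(-c2ccc(C(F)(F)F)cc2)nn1` gives 720 nM in a functional assay on HL-60 cells (Homo sapiens) for cytotoxicity, read by MTT assay, with a stated time of 4 days; on this read-out higher numbers stand for weaker inhibition and lower numbers for stronger inhibition.
Compound 2 `C=C1C(=O)[C@]23C[C@@]1(O)CC[C@H]2c1ccc(O)c(C)c1[C@@H]3Cn1cc(-c2ccc(Cl)cc2)nn1` gives 690 nM in this assay.
Compound 3 `C=C1C(=O)[C@]23C[C@@]1(O)CC[C@H]2c1ccc(O)c(C)c1[C@@H]3Cn1cc(-c2ccccn2)nn1` gives 1970 nM in this assay.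

Compound 3 carries the highest number of the three: a 2.7-fold higher number from compound 1 to compound 3 (0.44 log units; beyond the scatter) and a 2.9-fold higher number from compound 2 to compound 3 (0.46 log units; beyond the scatter), whereas a 1.0-fold lower number from compound 1 to compound 2 (0.02 log units; within the scatter). Compound 4 `C=C1C(=O)[C@]23C[C@@]1(O)CC[C@H]2c1ccc(O)c(C)c1[C@@H]3Cn1cc(-c2ccccc2)nn1` differs from compound 3 in one place: phenyl in place of pyridin-2-yl on an aromatic carbon. For the measured compounds named here, no measured step exchanges pyridin-2-yl for plain phenyl, but the two steps that end at compound 3 both show the phenyl-bearing compounds sitting well below it, so a return toward those numbers is expected. On that basis compound 4 is expected to show a modest downward step in this assay, a 2.0-fold lower number from compound 3 to compound 4 (0.29 log units; within the scatter). Compound 4 is therefore estimated at 1000 nM, with a range from 500 nM to 2000 nM.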

Compound 4, half-maximal inhibitory concentration: 750 nM
Beside the measured number, compound 4's estimate is 1.3-fold (0.12 log units) above it; the range from low to high includes it.
By their numbers in this assay, from the lowest: compounds 2, 1 and 4 (each within the scatter of the next); then compound 3.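

In this assay the swap of pyridin-2-yl for phenyl gives a 2.6-fold lower number from compound 3 to compound 4 (0.42 log units; beyond the scatter) on its own, so the higher number goes with pyridin-2-yl and not with the loss of the chloro or trifluoromethyl group. Unsubstituted phenyl stands level with both substituted phenyls: the steps are a 1.1-fold higher number from compound 2 to compound 4 (0.04 log units; within the scatter) and a 1.0-fold higher number from compound 1 to compound 4 (0.02 log units; within the scatter), so neither group moves the number beyond the scatter. Nothing given here explains the pyridin-2-yl difference. The compounds shown leave open whether an amine or a carboxylic acid on that phenyl would shift the number.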